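Swapping a Six-Membered Ring for a Pyrazole

A few compounds are considered here, and "the series" means these few. Any claim that something is new, unique, unknown or untested is made for them only; others in the source may bear on it.

Measured compounds:
compound 1, `COc1ccc(-c2nn3c(-c4cccs4)nnc3s2)cc1OC`: 0.99
compound 2, `c1csc(-c2nnc3sc(-c4cnccn4)nn23)c1`: 0.99

Both measured compounds were run in an ADME assay on microsomes from liver (Mus musculus), read by HPLC, using NADPH, with a stated time of 10 min; on this read-out lower numbers stand for lower hepatic extraction and higher numbers for higher hepatic extraction. Compound 1 gives 0.99, and compound 2 gives 0.99. The two values are level at the digits shown, so compound 2 stands together with compound 1 at the top end of the scale, with no difference between them beyond the scatter of repeated runs.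

Compound 3, `Cc1cc(-c2nn3c(-c4cccs4)nnc3s2)n[nH]1`, has not yet been measured. It differs from compound 2 in one place: 5-methyl-1H-pyrazol-3-yl in place of pyrazin-2-yl on an aromatic carbon.

Among the measured compounds shown here, no step between two measured compounds is available to guide this change, so the expectation rests on where compound 2 already sits. Since compound 2 lies close to the ceiling of this assay, there is little room for a rise, and the most that seems plausible is a small drop or no change beyond the scatter. The step a number 0.040 lower from compound 2 to compound 3 (within the scatter) is the expected one. Compound 3 is therefore estimated at 0.95, within a range from 0.85 to 0.99.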

Compound 3, hepatic extraction ratio in the liver assay: 0.97
The estimate for compound 3 lay 0.020 below the measured number, within the range that was stated.
By their numbers in the liver assay, from the lowest: compounds 3, 1 and 2 (each within the scatter of the next).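

In the liver assay the swap of pyrazin-2-yl for 5-methyl-1H-pyrazol-3-yl on this aromatic carbon gives a number 0.020 lower from compound 2 to compound 3 (within the scatter), so a five-membered ring with a hydrogen-bond donor leaves hepatic extraction level with the six-membered ring, still close to the top of the scale. In a physicochemical assay for solubility, measured as kinetic solubility (a lower number here means a less soluble compound, a higher number a more soluble compound), compound 2 gives 30000 nM and compound 3 gives 58000 nM, that is a 1.9-fold higher number from compound 2 to compound 3 (0.29 log units; within the scatter), so this change shows no clear effect on that read-out either. Nothing available here offers a reason for either result.

The ring and its methyl change together in this one step, so their separate contributions cannot be told apart. Going by these compounds, whether a non-aromatic group at this position, such as an amine, a carboxylic acid or a longer chain, would bring hepatic extraction down remains open.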